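Methoxy to Acetoxy on the Shared Core

The compounds below may be only part of what the source reports. "The series", "measured", "known", "first", "only" and "open" are said of these compounds alone.

Going by the values given here, compound 2 `COCCSCC1CN(C)CCC1c1ccc(Cl)cc1` holds the lowest of the two numbers so far in an assay on isolated protein for inhibition of Norepinephrine transporter (Rattus norvegicus), read by radioligand binding (on this read-out higher numbers stand for weaker inhibition and lower numbers for stronger inhibition), giving 6 nM. Among the compounds with values here, compound 1 `COC(=O)C[S+]([O-])CC1CN(C)CCC1c1ccc(Cl)cc1` gives 53 nM, and the single measured step is an 8.8-fold lower number from compound 1 to compound 2 (0.95 log units; beyond the scatter). Compound 3 `CC(=O)OCCSCC1CN(C)CCC1c1ccc(Cl)cc1` differs from compound 2 by acetyl in place of methyl on an oxygen on a saturated carbon. Within the data shown here, no measured step alters this oxygen alone; the step from compound 1 to compound 2 reworks the whole chain and does not bear on it directly. Compound 3 is therefore expected to stay close to compound 2, with an estimated step of a 1.7-fold higher number from compound 2 to compound 3 (0.22 log units; within the scatter) toward a somewhat higher number. The estimate for compound 3 is 10 nM, ranging from 3 nM to 30 nM.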

Compound 3, inhibition constant: 3.6 nM
Estimate against measurement, compound 3: 2.8-fold (0.44 log units) above, within the range that was stated.
By their numbers in this assay, from the lowest: compounds 3 and 2 (each within the scatter of the next); then compound 1.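

In this assay, going by these compounds alone, the swap of methoxy for acetoxy, the first change confined to this oxygen on a saturated carbon, gives a 1.7-fold lower number from compound 2 to compound 3 (0.22 log units; within the scatter), so the 2-acetoxyethyl chain serves as well as the 2-methoxyethyl chain. The larger shift lies in the wider rework of the chain, with a 15-fold lower number from compound 1 to compound 3 (1.17 log units; beyond the scatter), and no measurement shown explains either step. The compounds shown leave open whether this oxygen can carry a free hydroxyl or a benzoyl group with the number unchanged. They also leave open how an amine at this place, or a longer chain, would read.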